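Replacing the benzyl group on the aromatic nitrogen

The source may report more compounds than this note shows. Statements on the series, on what has been measured and on what is new or still open speak of the compounds shown alone.

Of the compounds shown here, two of the shared core have been measured in a functional assay with Homo sapiens as the target; a lower number here means a stronger inhibitor, a higher number a weaker inhibitor. Compound 1 `Cc1c(C(=O)Nc2ccc(C(F)(F)F)cc2)cnn1Cc1ccc(F)cc1` gives 3600 nM, the higher of the two numbers, while compound 2 `Cc1c(C(=O)N(CC(=O)O)c2ccc(C(F)(F)F)cc2)cnn1-c1ccc(F)cc1` gives 3200 nM; the two values sit within the usual scatter of this assay, so no order between them can be read. Compound 3 `Cc1cccc(-n2ncc(C(=O)Nc3ccc(C(F)(F)F)cc3)c2C)c1` carries 3-methylphenyl in place of 4-fluorobenzyl on an aromatic nitrogen. Within the data shown here, no step between measured compounds covers this change, so the expectation rests only on the two measured values. For compound 3 a step of a 1.4-fold lower number from compound 1 to compound 3 (0.16 log units; within the scatter) is expected, not clearly beyond the scatter. Compound 3 is estimated at 2500 nM, range 900 nM to 7000 nM.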

Compound 3, half-maximal inhibitory concentration: 2500 nM
For compound 3 middle estimate and measured number coincide at the digits printed, within the range that was stated.
By their numbers in this assay, from the lowest: compounds 3, 2 and 1 (each within the scatter of the next).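

In this assay, 3-methylphenyl in place of 4-fluorobenzyl on an aromatic nitrogen gives a 1.4-fold lower number from compound 1 to compound 3 (0.16 log units; within the scatter). Compound 1 and compound 3 differ in this one place, so this pair gives a reading of the position that compound 1 and compound 2 could not, and these two groups are not told apart here. No supporting measurement bears on this result.

From the compounds shown here alone, whether a group of another kind at this position, such as an amine or a longer chain, would give a step beyond the scatter remains open.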